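Swapping the pyridine for a benzamide on the shared core

A few compounds are considered here, and "the series" means these few. Any claim that something is new, unique, unknown or untested is made for them only; others in the source may bear on it.

Of the compounds shown here, three sharing a common core have been measured in an assay for inhibition of inositol hexakisphosphate kinase 3 (Homo sapiens), read by colorimetric assay, coupled enzyme assay and malachite green, with a stated time of 120 min, in the presence of a further agent that is not named here; a lower number here means a stronger inhibitor, a higher number a weaker inhibitor. Compound 2 `O=C(O)c1ccc2noc(-c3ccc(-c4ccncc4)cc3)c2c1` gives 670 nM, the lowest of the three numbers; compound 3 `O=C(O)c1ccc2noc(-c3ccc(Oc4ccccn4)cc3)c2c1` gives 2060 nM, and compound 1 `CNC(=O)/C=C/c1ccc2noc(-c3ccccc3)c2c1` gives 42600 nM. Compound 4 `O=C(O)c1ccc2noc(-c3ccc(NC(=O)c4ccccc4)cc3)c2c1` has not yet been measured; its change from compound 2 is benzamido in place of pyridin-4-yl on an aromatic carbon. For the measured compounds named here, the one measured step that bears on this place is a 3.1-fold higher number from compound 2 to compound 3 (0.49 log units; beyond the scatter), where a different ring, attached through a linking atom, replaced the same pyridin-4-yl. Since compound 4 likewise brings in a larger ring attached through a linker, a modest step in the same weakening direction is expected, giving a 2.7-fold higher number from compound 2 to compound 4 (0.43 log units; beyond the scatter). Compound 4 is therefore estimated at 1800 nM, within a range from 700 nM to 4500 nM.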

Compound 4, half-maximal inhibitory concentration: 200 nM
Estimate against measurement, compound 4: 9.0-fold (0.95 log units) above; measured number below the stated range.
By their numbers in this assay, from the lowest: compound 4; then compound 2; then compound 3; then compound 1.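

Not every larger group attached through a linker at this place raises the number: benzamido gives a 3.4-fold lower number from compound 2 to compound 4 (0.53 log units; beyond the scatter), the opposite direction to the earlier (pyridin-2-yl)oxy change. The two linked groups also stand well apart, with a 10-fold lower number from compound 3 to compound 4 (1.01 log units; beyond the scatter), so size and the presence of a linker do not set the result alone. Nothing available here bears on the reason for this difference.

Which part of benzamido goes with the lower number remains open. Acetamido or a sulfonamide at the same place would help separate the contribution of the ring from that of the linker.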